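Amine substituent variation on a naphthoquinone-derived sulfonyl amidine series

A few compounds are considered here, and "the series" means these few. Any claim that something is new, unique, unknown or untested is made for them only; others in the source may bear on it.

Three compounds of the series have numbers in a functional assay on A549 cells (Homo sapiens) for cytotoxicity, read by MTT assay, with a stated time of 48 h; a lower number here means a stronger inhibitor, a higher number a weaker inhibitor. Compound 3 `COc1cc(N/C(CCNC2=CC(=O)c3ccccc3C2=O)=N\S(=O)(=O)c2ccc(C)cc2)cc(OC)c1OC` gives 7940 nM and stands lowest of the three. Compound 1 `Cc1ccc(S(=O)(=O)/N=C(/CCNC2=CC(=O)c3ccccc3C2=O)Nc2cccc(C)c2)cc1` gives 18700 nM, and compound 2 `COc1ccc(N/C(CCNC2=CC(=O)c3ccccc3C2=O)=N\S(=O)(=O)c2ccc(C)cc2)cc1OC` gives 20500 nM. The step of a 2.4-fold lower number from compound 1 to compound 3 (0.37 log units; beyond the scatter) and the step of a 2.6-fold lower number from compound 2 to compound 3 (0.41 log units; beyond the scatter) both run beyond the scatter, while the step of a 1.1-fold higher number from compound 1 to compound 2 (0.04 log units; within the scatter) does not.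

Compound 4 `Cc1ccc(S(=O)(=O)/N=C(/CCNC2=CC(=O)c3ccccc3C2=O)NC2CCCCC2)cc1` is not yet measured. It differs from compound 3 by cyclohexyl in place of 3,4,5-trimethoxyphenyl on an amine nitrogen. The measured steps all exchange one aromatic substituent on this nitrogen for another, and the largest of them, from compound 1 to compound 3 and from compound 2 to compound 3, arrive at compound 3 through added methoxy groups. Within the data shown here, no measured step exchanges the aromatic ring on that nitrogen for a non-aromatic ring, so the bearing of the earlier steps is indirect. With the three methoxy groups and the aromatic ring gone, the number is expected to move back toward the level of compound 1 and compound 2, a step of about a 2.0-fold higher number from compound 3 to compound 4 (0.30 log units; within the scatter) upward. Compound 4 is therefore estimated at 16000 nM in this assay, within a range from 6000 nM to 45000 nM.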

Compound 4, half-maximal inhibitory concentration: 14700 nM
Estimate against measurement, compound 4: 1.1-fold (0.04 log units) above, within the range that was stated.
By their numbers in this assay, from the lowest: compounds 3, 4, 1 and 2 (each within the scatter of the next, the first and the last beyond it).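

In this assay, replacing the aromatic ring on this amine nitrogen with a non-aromatic ring gives a 1.9-fold higher number from compound 3 to compound 4 (0.27 log units; within the scatter), a 1.4-fold lower number from compound 2 to compound 4 (0.14 log units; within the scatter) and a 1.3-fold lower number from compound 1 to compound 4 (0.10 log units; within the scatter), so compound 4 cannot be told apart from any of the three aryl compounds. Within these four compounds, neither an aromatic ring nor methoxy groups are needed on this nitrogen to keep the number in this range, and the separation of compound 3 from compounds 1 and 2 does not extend to the cyclohexyl compound, which has no hydrogen-bond acceptors in this group. No supporting data are available to explain these numbers.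

Still open, as far as these compounds go, is whether a piperidine ring, a morpholine ring, a benzyl group or a longer open alkyl chain on this nitrogen would stay within the same band in this assay. The compounds shown also leave open whether a carboxylic acid or an amine on the ring would separate from this band, and whether the cyclohexyl and 3,4,5-trimethoxyphenyl compounds would stay indistinguishable on repeated measurement.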